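The compounds below may be only part of what the source reports. "The series", "measured", "known", "first", "only" and "open" are said of these compounds alone.

In a functional assay on A549 cells (Homo sapiens) for antiproliferative activity, read by MTT assay, with a stated time of 72 h (on this read-out lower numbers stand for stronger inhibition and higher numbers for weaker inhibition), compound 2 `O=C(Nc1ccc(Nc2nccc(Nc3ccccc3)n2)cc1)Nc1ccc(Cl)c(C(F)(F)F)c1` gives > 50000 nM, which is a limit of the assay and not a number. Among the measured compounds shown here, compound 1 `O=C(Nc1ccc(Nc2nccc(NC3CCCCC3)n2)cc1)Nc1ccc(Cl)c(C(F)(F)F)c1` gives 7430 nM, and the one measured step, an at least 6.7-fold higher number from compound 1 to compound 2 (0.82 log units; beyond the scatter), replaces cyclohexyl with phenyl on a nitrogen. Compound 3 `O=C(Nc1ccc(Nc2nccc(Nc3ccccc3Cl)n2)cc1)Nc1ccc(Cl)c(C(F)(F)F)c1` carries chloro in place of hydrogen on an aromatic carbon, chloro in place of hydrogen on an aromatic carbon, ortho to a large group. For the measured compounds named here, no measured step tests this chloro directly, so only a modest shift toward lower numbers is expected, and a second limit remains possible. The expected change is an at least 1.4-fold lower number from compound 2 to compound 3 (0.15 log units; that floor lies within the scatter). For compound 3 the estimated value is 35000 nM, with an expected range of 10000 nM to 50000 nM.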

Compound 3, half-maximal inhibitory concentration: 18600 nM
The estimate for compound 3 lay 1.9-fold (0.27 log units) above the measured number; measured number inside the range.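

Putting chloro in place of hydrogen on the phenyl ring, ortho to a large group, gives an at least 2.6-fold lower number from compound 2 to compound 3 (0.42 log units; beyond the scatter), so an aryl group on this nitrogen can return a readable number. Compound 2 stands at a limit of the assay and not at a number, so that step gives only a floor: the limit of > 50000 nM in this assay, at which 1 of the 3 values shown sits. Even so, 2-chlorophenyl on this nitrogen does not match cyclohexyl, with a 2.5-fold higher number from compound 1 to compound 3 (0.40 log units; beyond the scatter).

Going by these compounds, whether fluoro, methyl or methoxy at this place would act as chloro does stays open. Also open, on these data alone, is how a benzyl or piperidinyl group on this nitrogen would compare with cyclohexyl.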